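This account rests on a few compounds, and the source may have more. Where it says the series, first, only, none or still open, it means among the compounds named here.

Compound 1 `Cc1cc(/C=C2\SC(=O)NC2=O)c(C)n1-c1ccccc1C(F)(F)F` and compound 2 `Cc1cc(/C=C2/SC(=O)NC2=O)c(C)n1-c1ccccc1C(F)(F)F` are built from the same atoms and bonds and differ only in the configuration drawn at one double bond. In an ADME assay on L6 cells (Rattus norvegicus) for cytotoxicity, read by microscopy and resazurin assay, with a stated time of 72 h (a lower number here means that less compound is needed, a higher number that more compound is needed for the effect), compound 1 gives 64000 nM and compound 2 gives 43000 nM; the step of a 1.5-fold lower number from compound 1 to compound 2 (0.17 log units; within the scatter) is as small as one would expect from the fact that compounds 1 and 2 differ only in the configuration as drawn. Compound 3 `Cc1cc(/C=C2/SC(=N)NC2=O)c(C)n1-c1ccccc1C(F)(F)F` carries a different five-membered non-aromatic ring on the aromatic carbon; in this assay compound 3 gives 56000 nM. Compound 3 sits within the scatter of both neighbours, with a 1.1-fold lower number from compound 1 to compound 3 (0.06 log units; within the scatter) and a 1.3-fold higher number from compound 2 to compound 3 (0.11 log units; within the scatter).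

Compound 4 `Cc1cc(/C=C2/SC(=S)NC2=O)c(C)n1-c1ccccc1C(F)(F)F` differs from compound 3 by a group of 8 heavy atoms (4 carbon, 1 nitrogen, 1 oxygen, 2 sulfur; one five-membered non-aromatic ring with 2 hetero atoms) in place of a group of 8 heavy atoms (4 carbon, 2 nitrogen, 1 oxygen, 1 sulfur; one five-membered non-aromatic ring with 2 hetero atoms), on an aromatic carbon. The measured steps that resemble this one are the two exchanges of the same ring group, from compound 1 to compound 3 and from compound 2 to compound 3, and both stayed inside the scatter. Compound 4 is therefore expected to show no step beyond the scatter, no change at the digits printed from compound 3 to compound 4 (within the scatter). In this assay compound 4 is estimated at 56000 nM, with a likely range from 25000 nM to 125000 nM.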

Compound 4, half-maximal effective concentration: 9000 nM
Beside the measured number, compound 4's estimate is 6.2-fold (0.79 log units) above it; measured number below the stated range.
By their numbers in this assay, from the lowest: compound 4; then compounds 2, 3 and 1 (each within the scatter of the next).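

The ring group on this aromatic carbon is not as neutral as the earlier exchanges suggested: with the group holding 2 sulfur atoms, this assay shows a 6.2-fold lower number from compound 3 to compound 4 (0.79 log units; beyond the scatter). The same group also gives a 4.8-fold lower number from compound 2 to compound 4 (0.68 log units; beyond the scatter), and a 7.1-fold lower number from compound 1 to compound 4 (0.85 log units; beyond the scatter). Among the ring groups shown, this is the only one that stands apart from the others, needing less compound for the effect, whereas the other ring groups remain within the scatter of one another.

Nothing available here accounts for this drop. The compounds shown also leave open whether the other drawn configuration at the double bond behaves the same way with this ring group, and whether a carboxylic acid or a longer chain attached to that group would keep the lower number.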